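The source may report more compounds than this note shows. Statements on the series, on what has been measured and on what is new or still open speak of the compounds shown alone.

Three compounds share one core and differ only in the outer aromatic group. Compound 1 `OC[C@H]1O[C@H](Oc2ccc(-c3ccccc3Cl)cc2Cl)[C@@H](O)[C@@H](O)[C@@H]1O` gives 3.1 in a physicochemical assay for lipophilicity, read by LC-MS, measured as octanol-water partition, with a stated time of 2 h, at pH 7.4, tested at 1 uM; a lower number here means a more polar compound, a higher number a more lipophilic compound. Compound 2 `OC[C@H]1O[C@H](Oc2ccc(-c3ccc(C(F)(F)F)cc3)cc2Cl)[C@@H](O)[C@@H](O)[C@@H]1O` gives 3.4 in this assay. Compound 3 `O=[N+]([O-])c1ccc(-c2ccc(O[C@H]3O[C@H](CO)[C@@H](O)[C@H](O)[C@@H]3O)c(Cl)c2)cc1` gives 2.3 in this assay, the lowest of the three numbers, with compound 1 nearest to it and compound 2 furthest from it. The step of a number 0.80 log units lower from compound 1 to compound 3 (beyond the scatter) was modest, and the step of a number 1.10 log units lower from compound 2 to compound 3 (beyond the scatter) was large. Compound 4 `O=[N+]([O-])c1cccc(-c2ccc(O[C@H]3O[C@H](CO)[C@@H](O)[C@H](O)[C@@H]3O)c(Cl)c2)c1` has not yet been measured; its change from compound 3 is 3-nitrophenyl in place of 4-nitrophenyl on an aromatic carbon, the same atoms joined differently, at a place on an aromatic carbon of a six-membered aromatic ring of carbon only. Neither measured step is of this kind: both replaced one group with a different group rather than rearranging the same group, so neither bears directly on the change in hand. For the measured compounds named here, with no step of the same kind among the measured compounds, a step within the scatter is expected, a number 0.10 log units higher from compound 3 to compound 4 (within the scatter). Compound 4 is therefore expected to give 2.4 in this assay, within an estimated range from 2 to 2.8.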

Compound 4, distribution coefficient: 2.4
Beside the measured number, compound 4's estimate shows no gap at the digits printed; the range from low to high includes it.
By their numbers in this assay, from the lowest: compounds 3 and 4 (each within the scatter of the next); then compounds 1 and 2 (each within the scatter of the next).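

In this assay, for the compounds shown here, the step, a number 0.10 log units higher from compound 3 to compound 4 (within the scatter), is the first case here of the same atoms being rearranged rather than one group replacing another, and it shows that 3-nitrophenyl and 4-nitrophenyl cannot be told apart at this place on the shared core. The second step, a number 0.70 log units lower from compound 1 to compound 4 (beyond the scatter), lies beyond the scatter, as the earlier step from 2-chlorophenyl to 4-nitrophenyl did, so the separation from compound 1 holds for both nitrophenyl arrangements. Nothing available explains why the two arrangements give values so close together, so the result stands as an observation without a cause.

Going by these compounds, this single pair concerns only the nitro group, so it remains open whether rearranging a different group on the outer ring would also leave the number within the scatter. On these data alone, it is likewise open how an amine or a carboxylic acid would behave on that ring, both relative to the nitrophenyl compounds and when rearranged in the same way.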